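The source may report more compounds than this note shows. Statements on the series, on what has been measured and on what is new or still open speak of the compounds shown alone.

Measured in a toxicity assay on MDCK cells (Canis lupus familiaris) for cytotoxicity, read by crystal violet staining, with a stated time of 48 h; a higher number here means that more compound is tolerated, a lower number that less compound is tolerated:
Compound 1 `Cc1ccc2[nH]c(=O)c(CN(Cc3ccc(F)cc3)Cc3ccc(C(C)(C)C)cc3)cc2c1`: > 27000 nM
Compound 2 `CCc1ccc2[nH]c(=O)c(CN(Cc3ccc(F)cc3)Cc3ccc(C(C)(C)C)cc3)cc2c1`: > 33000 nM
Compound 3 `Cc1ccc2[nH]c(=O)c(CN(Cc3ccc(F)cc3)Cc3ccc(-c4ccccc4)cc3)cc2c1`: > 5000 nM

None of these three entries is an exact number. For compound 1, > 27000 nM is a limit of the assay, so its place among the three cannot be ranked. Compound 4 `Cc1ccc2[nH]c(=O)c(CN(Cc3ccc(OCC(=O)O)cc3)Cc3ccc(C(C)(C)C)cc3)cc2c1` keeps the core of compound 1 and changes a single group: carboxymethoxy in place of fluoro on an aromatic carbon, para to a large group (carboxymethoxy in place of fluoro on an aromatic carbon).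

Two measured steps start from compound 1, and neither makes this change. They are a step that the two limits leave unreadable from compound 1 to compound 2 and a step that the two limits leave unreadable from compound 1 to compound 3. Going by the values given here, neither offers a size to carry over, and no measured compound holds the carboxymethoxy group. With no measured loss to draw on, no step beyond the usual scatter is expected in this assay, in either direction. This expectation leans on compound 1 and its limit of > 27000 nM, so the new result may well be reported as a limit too. The expected step is a step that the limit leaves unreadable from compound 1 to compound 4. The estimate for compound 4 is 40000 nM. The expected range for compound 4 runs from 10000 nM to 120000 nM.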

Compound 4, half-maximal cytotoxic concentration: > 10000 nM
Compound 4: no number, only a limit; the forecaster's own chance of this, stated with the estimate: 70%; the middle value lies beyond the limit too.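

In this assay compound 4 gives > 10000 nM, which is a limit of the assay and not a number. Compound 1 also carries only a limit, so no step can be read from compound 1 to compound 4. The compounds shown leave open whether carboxymethoxy in place of fluoro changes how much compound is tolerated at all.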